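Desmethyl Analogue in a Thiourea Series: Cytotoxicity Outlook

This account rests on a few compounds, and the source may have more. Where it says the series, first, only, none or still open, it means among the compounds named here.

Three members of the series have been run in a functional assay on B16-F10 cells (Mus musculus) for cytotoxicity, read by MTT assay, with a stated time of 48 h; a lower number here means a stronger inhibitor, a higher number a weaker inhibitor. Compound 1 `S=C(Nc1ccc(Cl)cc1)Nc1nc2ccccc2s1` gives > 50000 nM in this assay, which is a limit of the assay and not a number. Compound 2 `Fc1ccc(NC(=S)Nc2nc3ccccc3s2)cc1` likewise returns only a limit, > 50000 nM. The step that the two limits leave unreadable from compound 1 to compound 2 is therefore not readable. Compound 3 `Cc1ccc2nc(NC(=S)Nc3ccccc3)sc2c1` gives > 50000 nM in this assay, again a limit rather than a number. Compound 3 thus stands at the limit of > 50000 nM in this assay, at which 3 of the 3 values shown sit; no value in the set has yet been resolved into a number, and nothing distinguishes the three on the evidence so far.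

Compound 4 `S=C(Nc1ccccc1)Nc1nc2ccccc2s1` differs from compound 3 by hydrogen in place of methyl on an aromatic carbon. Among the compounds with values here, no measured step bears directly on this change: the only step available is unreadable, and the methyl-bearing compound 3 sits at the same limit as the other two. With every value on the limit, the expected step of a number no higher from compound 3 to compound 4 (the limit leaves the size open) is nil beyond the scatter. Compound 4 is accordingly expected to give 50000 nM in this assay. The estimated range for compound 4 spans 15000 nM to 200000 nM, with a limit again the most likely report.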

Compound 4, half-maximal inhibitory concentration: > 50000 nM
Compound 4 ended at the assay's limit; the forecaster's own chance of this, stated with the estimate: 80%; the middle value lies on the limit itself.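

Compound 4 returns only a limit, as do compound 1, compound 2 and compound 3, so no step among these compounds can be read. In this assay the compounds shown leave open whether any change on the shared core gives a resolved number.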